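A few compounds are considered here, and "the series" means these few. Any claim that something is new, unique, unknown or untested is made for them only; others in the source may bear on it.

Working notes on the series. All compounds are tested in a functional assay on the whole organism for inhibition, with Rattus norvegicus as the target; on this read-out higher numbers stand for an effect only at larger amounts of compound and lower numbers for an effect already at smaller amounts. Compound 1 `CC1CC/C(=N\Nc2ccc(Br)cc2)c2ncc(C(=O)O)c(=O)n21` gives 0.8 umol/kg in this assay. Among the measured compounds shown here, compound 2 `Cc1ccc(N/N=C2\CCC(C)n3c2ncc(C(=O)O)c3=O)cc1` gives 1.3 umol/kg in this assay; of the two numbers so far, compound 2 sits at the upper one, with compound 1 nearest, and the only measured step, a 1.6-fold higher number from compound 1 to compound 2 (0.21 log units; within the scatter), remains within the scatter. Compound 3 `CC(C)c1ccc(N/N=C2\CCC(C)n3c2ncc(C(=O)O)c3=O)cc1` is not yet measured. It differs from compound 2 by isopropyl in place of methyl on an aromatic carbon. For the measured compounds named here, the only step that bears on this change is the exchange of groups on an aromatic carbon, a 1.6-fold higher number from compound 1 to compound 2 (0.21 log units; within the scatter), which was within the scatter; no measured step yet tests a larger group at this place. The expected step from compound 2 to compound 3 in this assay is therefore a 1.2-fold higher number from compound 2 to compound 3 (0.09 log units; within the scatter), not beyond the scatter, leaning toward a higher number. Compound 3 is estimated at 1.6 umol/kg, with a range from 0.7 umol/kg to 4 umol/kg.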

Compound 3, dose for 50% inhibition: 2.4 umol/kg
Compound 3: middle estimate off by 1.5-fold (0.18 log units), on the low side; measured number inside the range.
By their numbers in this assay, from the lowest: compounds 1, 2 and 3 (each within the scatter of the next, the first and the last beyond it).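

In this assay the change from methyl to isopropyl gives a 1.8-fold higher number from compound 2 to compound 3 (0.27 log units; within the scatter) and so still stays inside the scatter, which means this place on the aromatic ring carries a group of three heavy atoms without a step that can be read as a change. Among the compounds shown here, the exchange of bromo for isopropyl at the same place gives a 3.0-fold higher number from compound 1 to compound 3 (0.48 log units; beyond the scatter) and is the first step to pass the scatter, though only modestly, so the choice of group here does show in this read-out. No measurement in hand accounts for this step.

On these data alone, whether an amine, a carboxylic acid or a longer chain such as n-butyl at this place would move the number further remains open. So does whether a group on another carbon of this aromatic ring would give a step of similar size.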